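The source may hold more compounds than are shown below. What is called first, only, known or untested is meant among the compounds shown, and "the series" means these compounds.

Compound 1 `CCOC(=O)C1=C(C)NC(SC)=NC1c1cccc([N+](=O)[O-])c1`: 23 nM
Compound 2 `CCOC(=O)C1=C(C)NC(SC)=NC1c1ccccc1C(F)(F)F`: 35 nM

Of the compounds shown here, two have been measured in an assay on Myocardium (Cavia porcellus) for binding affinity to Voltage-dependent L-type calcium channel subunit alpha-1C (Homo sapiens); a higher number here means weaker binding, a lower number tighter binding. Compound 1 gives 23 nM, and compound 2 gives 35 nM. The two numbers lie within the usual scatter of this measurement, so neither can be called the tighter binder. Compound 1 holds the lower of the two numbers, but only by a margin that repeated measurements could erase. Among the compounds with values here, no pair among the measured compounds differs in just one place, so no measured step is available to guide expectations.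

Compound 3 `CSC1=NC(c2cccc([N+](=O)[O-])c2)C(C(=O)OC(C)C)=C(C)N1` has not yet been measured. It differs from compound 1 in one spot: methyl in place of hydrogen on a saturated chain carbon bound to an oxygen next to a carbonyl group and a saturated chain carbon. Put another way, the ethyl group of compound 1 becomes an isopropyl group, so the ethoxycarbonyl becomes an isopropoxycarbonyl, while the shared core is untouched.

Within the data shown here, with no measured step of this type, the expectation rests on the nature of the change alone. A methyl in place of hydrogen at this spot is a minor structural change, and the expected step of a 1.2-fold lower number from compound 1 to compound 3 (0.06 log units; within the scatter) is none beyond the scatter, in either direction. Compound 3 is therefore estimated at 20 nM in this assay, with a range from 7 nM to 60 nM.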

Compound 3, dissociation constant: 12 nM
Estimate against measurement, compound 3: 1.7-fold (0.22 log units) above, and the stated range covers the measured number.
By their numbers in this assay, from the lowest: compounds 3, 1 and 2 (each within the scatter of the next, the first and the last beyond it).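

The change from ethyl to isopropyl at this position gives the series its first measured one-place step, with a 1.9-fold lower number from compound 1 to compound 3 (0.28 log units; within the scatter) as its size in this assay. A step of this size cannot be called a real gain or a real loss, so the data show only that one added methyl on this saturated chain carbon, bound to an oxygen next to a carbonyl group, leaves the binding number within the reach of ordinary repeat measurements. No measurement is at hand that could explain this result.

From the compounds shown here alone, it remains open how much larger the group at this position can become before the number moves beyond the scatter, as a tert-butyl group, a longer chain such as butyl, or a benzyl group could show. Going by these compounds, it is also open whether the same step from ethoxycarbonyl to isopropoxycarbonyl would give a similar result on compound 2, which carries a trifluoromethyl group where compound 1 carries its nitro group.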